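The compounds below may be only part of what the source reports. "The series", "measured", "known", "first", "only" and "open" are said of these compounds alone.

Two compounds have numbers in an assay on HEK293 cells for displacement of a labelled ligand from prostaglandin D2 receptor 2 (Homo sapiens); a lower number here means a stronger inhibitor, a higher number a weaker inhibitor. Compound 1 `O=C(O)Cn1c(SCc2ccccc2Cl)nc2ccccc21` gives 370 nM, and compound 2 `COc1ccc(CSc2nc3ccccc3n2CC(=O)O)cc1` gives 210 nM. Compound 2 has the lower of the two numbers, but its gap to compound 1 falls within the usual scatter, so neither stands apart. Compound 3 `COC(=O)c1ccc(CSc2nc3ccccc3n2CC(=O)O)cc1` differs from compound 2 by methoxycarbonyl in place of methoxy on an aromatic carbon. Among the compounds with values here, no measured pair shows what such a change does here, so only a small step is expected, a 1.2-fold higher number from compound 2 to compound 3 (0.08 log units; within the scatter), in either direction or none beyond the scatter. For compound 3 the expected value in this assay is 250 nM, with a range from 80 nM to 800 nM.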

Compound 3, half-maximal inhibitory concentration: 10600 nM
Compound 3: the middle estimate sits 42-fold (1.63 log units) below what was measured; measured number outside the range, above it.
By their numbers in this assay, from the lowest: compounds 2 and 1 (each within the scatter of the next); then compound 3.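

The aromatic carbon para to a large group does not tolerate every change in this assay: methoxycarbonyl in place of methoxy gives a 50-fold higher number from compound 2 to compound 3 (1.70 log units; beyond the scatter). Within the data shown here, this is the first step that can be read between compounds differing in one place, and it lies well beyond the scatter. A single step, however, describes only this one replacement. From the compounds shown here alone, whether a carboxylic acid, an amide or a nitrile on this carbon would give a similar loss stays open. Nothing measured here explains the size of the step.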